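A few compounds are considered here, and "the series" means these few. Any claim that something is new, unique, unknown or untested is made for them only; others in the source may bear on it.

Among the measured compounds shown here, in an ADME assay on liver (Mesocricetus auratus) for metabolic stability, using microsomes (a higher number here means faster removal of the compound, a lower number slower removal), compound 1 `N#Cc1ccc(OC2CCN(C(=O)Nc3cc(-c4ccccn4)n[nH]3)CC2)cc1` gives 30.8 mL.min-1.g-1 as the only actual number so far. Compound 2 `O=C(Nc1[nH]nc(-c2ccccn2)c1C1CC1)c1c(Cl)cccc1Cl` shows > 100 mL.min-1.g-1 as a limit of the assay, not a number. Compound 3 `O=C(Nc1cc(-c2ccccn2)n[nH]1)N1CCC(Oc2ccccn2)CC1` keeps the core of compound 1 and carries pyridin-2-yl in place of 4-cyanophenyl on an oxygen on a saturated carbon. For the measured compounds named here, no measured pair shows what this swap does. In this assay no step beyond the usual scatter is expected, and the estimated step of a 1.1-fold higher number from compound 1 to compound 3 (0.03 log units; within the scatter) is small. Compound 3 is estimated at 33 mL.min-1.g-1 with 14 mL.min-1.g-1 to 75 mL.min-1.g-1 as the expected range.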

Compound 3, intrinsic clearance in microsomes: 67.3 mL.min-1.g-1
Beside the measured number, compound 3's estimate is 2.0-fold (0.31 log units) below it; measured number inside the range.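

In this assay, among the compounds shown here, the swap gives the only measured step at this place, and it lies beyond the usual scatter (a 2.2-fold higher number from compound 1 to compound 3 (0.34 log units; beyond the scatter)). With the core of compound 1 unchanged, the group on this oxygen can by itself shift the clearance, and removal is slower with 4-cyanophenyl than with pyridin-2-yl. Nothing in the data shown accounts for this step. The swap removes the nitrile and adds a ring nitrogen together, so the two cannot be told apart. Plain phenyl or a small alkyl amine at this place remains open.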